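The source may hold more compounds than are shown below. What is called first, only, known or untested is meant among the compounds shown, and "the series" means these compounds.

- compound 1 `C=C(Br)C(=O)Nc1ccc(/C=C/C(=O)c2ccc(Cl)cc2)cc1` gives 1100 nM
- compound 2 `C=C(Br)C(=O)Nc1ccc(/C=C/C(=O)c2ccc(Cl)c(Cl)c2)cc1` gives 2100 nM

In a functional assay on L1210 cells (Mus musculus) for antiproliferative activity, with a stated time of 48 h (on this read-out higher numbers stand for weaker inhibition and lower numbers for stronger inhibition), compound 2 gives 2100 nM and stands within the scatter of compound 1. Compound 3 (`C=C(Br)C(=O)Nc1ccc(/C=C/C(=O)c2ccc(Br)cc2)cc1`) brings 4-bromophenyl in place of 3,4-dichlorophenyl on a carbonyl carbon in words, 4-bromophenyl in place of 3,4-dichlorophenyl on a carbonyl carbon. Among the compounds with values here, the one measured step bearing on this is a 1.9-fold higher number from compound 1 to compound 2 (0.28 log units; within the scatter) for chloro in place of hydrogen on an aromatic carbon, and it lies within the scatter. Within the data shown here, with only that step to go on, no step beyond the scatter is expected for compound 3 in this assay on this evidence. The estimated step is a 1.5-fold lower number from compound 2 to compound 3 (0.18 log units; within the scatter) on that basis. For compound 3 the expected value is 1400 nM with an estimated range of (700 nM to 2800 nM).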

Compound 3, half-maximal inhibitory concentration: 620 nM
Estimate against measurement, compound 3: 2.3-fold (0.35 log units) above; the measured number lies below the stated range.
By their numbers in this assay, from the lowest: compounds 3, 1 and 2 (each within the scatter of the next, the first and the last beyond it).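

In this assay, within the data shown here, a change on the carbonyl carbon now gives a 3.4-fold lower number from compound 2 to compound 3 (0.53 log units; beyond the scatter) for 4-bromophenyl in place of 3,4-dichlorophenyl, the first step here beyond the scatter. Bromo in place of chloro gives a 1.8-fold lower number from compound 1 to compound 3 (0.25 log units; within the scatter) and stays within the scatter, so the single-halogen compounds cannot be told apart in this test. Nothing measured here explains either step.

On these data alone, how a ring bearing an amine or a carboxylic acid instead of halogen would behave remains open. So does the effect of a methoxy group on the same ring.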